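Series notes: from compound 2 to compound 3

A few compounds are considered here, and "the series" means these few. Any claim that something is new, unique, unknown or untested is made for them only; others in the source may bear on it.

Compound 1 `C[Se]/C(=N\C(=O)c1cc2ccccc2s1)NC(=O)c1cc2ccccc2s1` and compound 2 `CS/C(=N\C(=O)c1cc2ccccc2s1)NC(=O)c1cc2ccccc2s1` share one core and differ only in the small group on the carbon with a double bond to nitrogen. In a functional assay on K562 cells (Homo sapiens) for cytotoxicity, read by MTT assay, with a stated time of 72 h (a higher number here means a weaker inhibitor of growth, a lower number a stronger inhibitor of growth), compound 1 gives 61000 nM, and compound 2 gives 66600 nM. The step of a 1.1-fold higher number from compound 1 to compound 2 (0.04 log units; within the scatter) lies within the scatter, so the two values cannot be ordered. Of the two numbers measured, compound 2 holds the highest, with compound 1 nearest.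

Compound 3 `O=C(/N=C(/NC(=O)c1cc2ccccc2s1)[Se]Cc1ccccc1)c1cc2ccccc2s1` has not yet been measured. Relative to compound 2 it carries a group of 8 heavy atoms (7 carbon, 1 selenium; one six-membered aromatic ring of carbon only) in place of a group of 2 heavy atoms (1 carbon, 1 sulfur; no ring), on a carbon with a double bond to nitrogen. For the measured compounds named here, the only measured step at this carbon, a 1.1-fold higher number from compound 1 to compound 2 (0.04 log units; within the scatter), exchanged selenium for sulfur and stayed within the scatter; no measured step covers the benzyl part of the change, so that part has no precedent. The chalcogen part is expected to be neutral, and for compound 3 the expected step is a 1.2-fold lower number from compound 2 to compound 3 (0.08 log units; within the scatter). Compound 3 is estimated at 55000 nM, within a range of 18000 nM to 160000 nM.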

Compound 3, concentration for total growth inhibition: 42800 nM
Beside the measured number, compound 3's estimate is 1.3-fold (0.11 log units) above it, and the stated range covers the measured number.
By their numbers in this assay, from the lowest: compounds 3, 1 and 2 (each within the scatter of the next).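

In this assay, for the compounds shown here, the first enlargement of the group on the carbon with a double bond to nitrogen, phenyl in place of hydrogen on a saturated chain carbon bound to a selenium atom, gives a 1.4-fold lower number from compound 1 to compound 3 (0.15 log units; within the scatter), and the full exchange from methylsulfanyl gives a 1.6-fold lower number from compound 2 to compound 3 (0.19 log units; within the scatter). This position therefore carries a group with a six-membered aromatic ring without any separation from the two small-group compounds, so across these three compounds neither the added ring nor the chalcogen orders the values. Nothing available bears on why the numbers stay together.

The compounds shown leave open whether a benzylsulfanyl group would match compound 3. They also leave open whether an amine, a carboxylic acid or a longer alkyl chain on the chalcogen would produce a step beyond the scatter.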